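A few compounds are considered here, and "the series" means these few. Any claim that something is new, unique, unknown or untested is made for them only; others in the source may bear on it.

Measured compounds:

compound 1 `COc1ccc(-c2cc(/C=C/C(=O)c3ccc(N)cc3)[nH]n2)cc1` with 36%
compound 2 `COc1cc(-c2cc(/C=C/C(=O)c3ccc(Cl)c(Cl)c3)[nH]n2)cc(OC)c1OC` with 33%
compound 3 `COc1ccc(C(=O)/C=C/c2cc(-c3cc(OC)c(OC)c(OC)c3)n[nH]2)cc1` with 27%

In a functional assay on RPMI-8226 cells (Homo sapiens) for cytotoxicity, read by sulforhodamine B assay, with a stated time of 48 h, tested at 1 uM (a higher number here means a weaker effect of the compound at the concentration tested, a lower number a stronger effect), compound 2 gives 33%. Among the three numbers, compound 2 stands second highest; its nearest neighbour is compound 1, whose number is three points higher, and its furthest is compound 3, whose number is six points lower, both gaps lying within the scatter. Among the compounds with values here, the single step at the same place, a number 6 percentage points lower from compound 2 to compound 3 (within the scatter), is also within the scatter.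

Compound 4 `COc1cc(-c2cc(/C=C/C(=O)c3ccc(F)c(F)c3)[nH]n2)cc(OC)c1OC` has not yet been measured. It differs from compound 2 as follows: 3,4-difluorophenyl in place of 3,4-dichlorophenyl on a carbonyl carbon

Within the data shown here, no measured step swaps one halogen pair for another on that carbonyl carbon, so nothing bears directly on this change. Among the measured compounds shown here, the one measured step at that position, a number 6 percentage points lower from compound 2 to compound 3 (within the scatter), was within the scatter, and no step beyond the scatter is therefore expected for no change at the digits printed from compound 2 to compound 4 (within the scatter). Compound 4 is estimated to give 33%, expected to lie between 20% and 48%.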

Compound 4, a percentage reported as activity, at one concentration (the size of the read-out at that concentration, not a potency): 73%
The estimate for compound 4 lay 40 percentage points below the measured number, and the stated range ends below it.
By their numbers in this assay, from the lowest: compounds 3, 2 and 1 (each within the scatter of the next); then compound 4.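

In this assay, the position on the carbonyl carbon turns out not to be indifferent to its aryl group: 3,4-difluorophenyl in place of 3,4-dichlorophenyl gives a number 40 percentage points higher from compound 2 to compound 4 (beyond the scatter), and in place of 4-methoxyphenyl it gives a number 46 percentage points higher from compound 3 to compound 4 (beyond the scatter). The earlier step, a number 6 percentage points lower from compound 2 to compound 3 (within the scatter), had shown no change beyond the scatter, so the effect at the concentration tested is clearly weakened only with the difluorinated ring. The two halogen-bearing groups match in heavy atoms, donors, acceptors and charge, and no measurement on hand accounts for the step.

The compounds shown leave open whether a single halogen, as in 4-fluorophenyl or 4-chlorophenyl, would follow compound 2 or compound 4. They also leave open how a larger pair, as in 3,4-dibromophenyl, would read at this position.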